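A Smaller Side Chain on a Compound Without Measurable Effect

The compounds below may be only part of what the source reports. "The series", "measured", "known", "first", "only" and "open" are said of these compounds alone.

Measured compounds:
compound 1 `COC(=O)Cn1n[n+]([O-])c2cc(C)c(C)cc21` — > 100 ug/mL
compound 2 `COC(=O)Cn1nc2c(n1)C(=O)C(C)=C(C)C2=O` — 4 ug/mL

Of the compounds shown here, two have been tested in a functional assay on KB cells (Homo sapiens) for inhibition, read by colorimetric assay, with a stated time of 72 h; on this read-out lower numbers stand for an effect already at smaller amounts and higher numbers for an effect only at larger amounts of compound. In this assay compound 1 gives > 100 ug/mL, which is a limit of the measurement rather than a number, so its true position is only known to sit at the limit of > 100 ug/mL in this assay, at which 1 of the 2 values shown sits. Compound 2, which has a different core, reaches a number in this assay, 4 ug/mL. For the measured compounds named here, no step between these two is set out, so nothing more is drawn from the pair.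

Compound 3 `Cc1cc2c(cc1C)[n+]([O-])nn2C` keeps the core of compound 1 and differs from it in one place: hydrogen in place of methoxycarbonyl on a saturated chain carbon bound to an aromatic nitrogen. Going by the values given here, because compound 1 gives only > 100 ug/mL, no measured step shows what this change does, and the step of a number no higher from compound 1 to compound 3 (the limit leaves the size open) is expected to be none beyond the scatter. Compound 3 is therefore expected to give about 100 ug/mL in this assay, within 30 ug/mL to 300 ug/mL, most likely again as a limit.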

Compound 3, concentration for half-maximal effect: > 100 ug/mL
Compound 3 was reported as a limit (the forecaster's own chance of this, stated with the estimate: 80%); the middle value sits exactly at the limit.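

Compound 1 and compound 3 both end at a limit of the measurement rather than a number, so no step can be read between them: the limit of > 100 ug/mL in this assay, at which 2 of the 3 values shown sit. Left open is whether methyl in place of (methoxycarbonyl)methyl on the shared core changes the result in this assay at all.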